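Fluoro for hydrogen: the same change in two matched pairs

This account rests on a few compounds, and the source may have more. Where it says the series, first, only, none or still open, it means among the compounds named here.

Measured compounds in a functional assay on A549 cells (Homo sapiens) for cytotoxicity, read by MTT assay, with a stated time of 72 h; on this read-out higher numbers stand for weaker inhibition and lower numbers for stronger inhibition:
Compound 1, `O=C(Nc1ccc(Oc2ccnc3[nH]ccc23)cc1)c1nn(-c2ccc(Cl)c(F)c2)ccc1=O`, gives 2580 nM.
Compound 2, `O=C(Nc1ccc(Oc2ccnc3[nH]ccc23)c(F)c1)c1nn(-c2ccc(Cl)c(F)c2)ccc1=O`, gives 10300 nM.
Compound 3, `Cn1ccc2c(Oc3ccc(NC(=O)c4nn(-c5ccc(Cl)cc5)ccc4=O)cc3)ccnc21`, gives only a limit of the assay, > 60000 nM.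

Compound 2 differs from compound 1 by fluoro in place of hydrogen on an aromatic carbon, and this change produced a 4.0-fold higher number from compound 1 to compound 2 (0.60 log units; beyond the scatter). Compound 4, `Cn1ccc2c(Oc3ccc(NC(=O)c4nn(-c5ccc(Cl)cc5)ccc4=O)cc3F)ccnc21`, is not yet measured; it differs from compound 3 by fluoro in place of hydrogen on an aromatic carbon, at a place described in the same words, so it is the same change, occurring twice among these compounds. The difference between the core of compound 1 and the core of compound 3 is not broken down here. Compound 3 sits at the limit of > 60000 nM in this assay, at which 1 of the 3 values shown sits, so no measured number anchors compound 4. Resting on the weakening seen in a 4.0-fold higher number from compound 1 to compound 2 (0.60 log units; beyond the scatter), compound 4 is expected to stay beyond that limit, estimated at 100000 nM. This estimate means an expected step that the limit leaves unreadable from compound 3 to compound 4.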

Compound 4, half-maximal inhibitory concentration: > 60000 nM
Compound 4 gave a limit, no number; the forecaster's own chance of this, stated with the estimate: 85%; the middle value lies beyond the limit too.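

Compound 3 and compound 4 both stand at a limit rather than at a number, so no step between them can be read: the limit of > 60000 nM in this assay, at which 2 of the 4 values shown sit.

On these data alone, what stays open is whether fluoro in place of hydrogen changes activity on the core of compound 3 as it did on the core of compound 1.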